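This account rests on a few compounds, and the source may have more. Where it says the series, first, only, none or still open, it means among the compounds named here.

Series in a functional assay on MKN-45 cells (Homo sapiens) for cytotoxicity, read by MTT assay, with a stated time of 72 h; on this read-out lower numbers stand for stronger inhibition and higher numbers for weaker inhibition:
- compound 1 `O=C(N/N=C/c1cccs1)N1CCc2ncnc(Nc3cccc(Br)c3)c2C1`: > 200000 nM
- compound 2 `O=C(N/N=C/c1ccco1)N1CCc2ncnc(Nc3cccc(Br)c3)c2C1`: 65700 nM

The entry for compound 1 is a limit of the assay, not a number. Among the compounds with values here, compound 2 therefore carries the only true number so far, and its standing can be read only against (the limit of > 200000 nM in this assay, at which 1 of the 2 values shown sits).

Next is compound 3 `O=C(N/N=C/c1cccnc1)N1CCc2ncnc(Nc3cccc(Br)c3)c2C1`, which has pyridin-3-yl in place of furan-2-yl on a carbon with a double bond to nitrogen.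

Within the data shown here, one measured step bears on this change, as it falls at the same place in the structure: an at least 3.0-fold lower number from compound 1 to compound 2 (0.48 log units; beyond the scatter). Among the measured compounds shown here, that step shows that this assay can respond to an exchange of this ring, but it involves only two five-membered rings and gives no direction for a six-membered one. As the central case, no shift beyond the scatter is expected, although a move of similar size either way remains possible. The expected step is a 1.1-fold lower number from compound 2 to compound 3 (0.04 log units; within the scatter). Compound 3 is estimated at 60000 nM, with an expected range of 15000 nM to 180000 nM.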

Compound 3, half-maximal inhibitory concentration: > 200000 nM
Compound 3 was reported as a limit (the forecaster's own chance of this, stated with the estimate: 25%); middle value at least 3.3-fold (0.52 log units) from the limit.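

In this assay compound 3 gives > 200000 nM, which is a limit of the assay and not a number. The exchange of furan-2-yl for pyridin-3-yl on the carbon with a double bond to nitrogen gives an at least 3.0-fold higher number from compound 2 to compound 3 (0.48 log units; beyond the scatter), so a six-membered aromatic ring with one hetero atom does not keep the measurable activity seen with furan-2-yl, and furan-2-yl is now the only one of the three rings shown that gives a true number, with thiophen-2-yl and pyridin-3-yl both going against any reading that an aromatic ring at this place is enough. The steps that join compound 1 and compound 3 cannot be read, since both ends are limits, and the series remains anchored on compound 2 alone: the limit of > 200000 nM in this assay, at which 2 of the 3 values shown sit.

Open, on these data alone, is whether any group at this place can bring the number well below that of compound 2, since even that compound sits far from a strong result on this read-out. A phenyl ring, pyridin-2-yl or a short alkyl chain such as propyl on this carbon would show whether furan-2-yl is a special case or only one point in a wider trend.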